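The source may report more compounds than this note shows. Statements on the series, on what has been measured and on what is new or still open speak of the compounds shown alone.

Measured compounds in an ADME assay on MT4 cells (Homo sapiens) for cytotoxicity, read by MTT assay, with a stated time of 5 days; a higher number here means that more compound is tolerated, a lower number that less compound is tolerated:
compound 1, `Cc1cc(C)c(Oc2cc(Nc3ccc(C#N)cc3)ncc2C(=O)NCc2cn(CC(N)=O)nn2)c(C)c1`, 24000 nM;
compound 2, `COC(=O)Cn1cc(CNC(=O)c2cnc(Nc3ccc(C#N)cc3)cc2Oc2c(C)cc(C)cc2C)nn1`, 13800 nM;
compound 3, `Cc1cc(C)c(Oc2cc(Nc3ccc(C#N)cc3)ncc2C(=O)NCc2cn(Cc3ccc([N+](=O)[O-])cc3)nn2)c(C)c1`, >= 139000 nM.

Compound 3 stands apart from the other two. Among the measured compounds shown here, its value is a limit of this assay rather than a number, and it is the only one of the three values that sits at the limit of >= 139000 nM in this assay, at which 1 of the 3 values shown sits. Compound 4, `CCOC(=O)CCn1cc(CNC(=O)c2cnc(Nc3ccc(C#N)cc3)cc2Oc2c(C)cc(C)cc2C)nn1`, differs from compound 3 by (ethoxycarbonyl)methyl in place of 4-nitrophenyl on a saturated chain carbon bound to an aromatic nitrogen. The measured steps that bear on this change run the other way: an at least 5.7-fold higher number from compound 1 to compound 3 (0.76 log units; beyond the scatter), and an at least 10-fold higher number from compound 2 to compound 3 (1.00 log units; beyond the scatter). Both show that the ester- or amide-bearing chains go with a lower number than the 4-nitrobenzyl. A step back to such a chain is therefore expected to lower the number, as an at least 6.9-fold lower number from compound 3 to compound 4 (0.84 log units; beyond the scatter). Compound 4 is estimated at 20000 nM, between 8000 nM and 60000 nM.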

Compound 4, half-maximal cytotoxic concentration: 21500 nM
Compound 4: the middle estimate sits 1.1-fold (0.03 log units) below what was measured; measured number inside the range.
By their numbers in this assay, from the lowest: compounds 2, 4 and 1 (each within the scatter of the next). At a limit, above all of these: compound 3.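

In this assay, a third chain without a ring, the 2-(ethoxycarbonyl)ethyl of compound 4, joins the other two at this position, with a 1.6-fold higher number from compound 2 to compound 4 (0.19 log units; within the scatter) and a 1.1-fold lower number from compound 1 to compound 4 (0.05 log units; within the scatter), so changing the ester group or the chain's length shows no readable effect here. Only the 4-nitrobenzyl stands apart, with an at least 6.4-fold lower number from compound 3 to compound 4 (0.81 log units; beyond the scatter). Compound 3 therefore gives only a limit, not a number: the limit of >= 139000 nM in this assay, at which 1 of the 4 values shown sits.

Still open, as far as these compounds go, is whether the ring alone or its nitro group goes with the higher number, which a plain benzyl would test. A carboxylic acid or an amine on the chain is also untested among these compounds.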